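Two Chromanone Cores, One Chain Change, and an Expected Value

A few compounds are considered here, and "the series" means these few. Any claim that something is new, unique, unknown or untested is made for them only; others in the source may bear on it.

Of the compounds shown here, three have been measured for their ability to slow the growth of a breast cancer cell line, in a functional assay on MDA-MB-231 cells (Homo sapiens) for antiproliferative activity, read by MTT assay; a higher number here means a weaker inhibitor, a lower number a stronger inhibitor. Compound 1 `CC/C=C\C/C=C\C/C=C\CCCCCCCC1(O)CC(=O)c2c(O)cc(O)cc2O1` gives 6790 nM. Compound 3 `CCCCC/C=C\C/C=C\CCCCCCCC1(O)CC(=O)c2c(O)cc(O)cc2O1` gives 6790 nM. Compound 2 `CCCCC/C=C\C/C=C\CCCCCCCC1(O)CC(=O)c2c(O)c(C)c(O)c(C)c2O1` gives 42800 nM, the highest of the three numbers, and its gap to either of the other two lies beyond the usual scatter. The difference between the core of compound 2 and the core of compound 3 is not broken down here.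

Compound 4 `CC/C=C\C/C=C\C/C=C\CCCCCCCC1(O)CC(=O)c2c(O)c(C)c(O)c(C)c2O1` has not yet been measured. It differs from compound 2 by but-1-en-1-yl in place of butyl on a saturated chain carbon bound to a double-bonded chain carbon. The same change, (but-1-en-1-yl in place of butyl on a saturated chain carbon bound to a double-bonded chain carbon), has already been made from compound 3 to compound 1, where the step was no change at the digits printed from compound 3 to compound 1 (within the scatter). Because that step from compound 3 to compound 1 was no change at the digits printed from compound 3 to compound 1 (within the scatter), the step from compound 2 to compound 4 in this assay is expected to be a 1.1-fold lower number from compound 2 to compound 4 (0.03 log units; within the scatter), staying close to the number of compound 2. On that basis compound 4 is estimated at 40000 nM, with a range from 15000 nM to 110000 nM.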

Compound 4, half-maximal inhibitory concentration: 42800 nM
Compound 4: the middle estimate sits 1.1-fold (0.03 log units) below what was measured, and the stated range covers the measured number.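

In this assay, putting but-1-en-1-yl in place of butyl on a saturated chain carbon bound to a double-bonded chain carbon gives no change at the digits printed from compound 2 to compound 4 (within the scatter). Set beside the same change on the other core, the two steps agree:

the same change on two cores in this assay, no change at the digits printed (within the scatter) from compound 3 to compound 1 and no change at the digits printed (within the scatter) from compound 2 to compound 4, 1.0-fold (0.00 log units) apart, within the scatter of two such steps

So in this small series, an extra double bond at this place in the chain leaves the number as it was on both cores, and a result from one core carried over to the other; this does not show that it would carry over to a third core, to a different change in the chain, or to another kind of test, and it does not say why the change makes no difference.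

The compounds shown leave open what happens when the chain is made much shorter or longer, or when it ends in a carboxylic acid or an amine rather than a plain carbon tail. They also leave open whether a step in the chain would stay this small with other groups on the core.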